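The source may report more compounds than this note shows. Statements on the series, on what has been measured and on what is new or still open speak of the compounds shown alone.

Measured so far in a functional assay on SNB-19 cells (Homo sapiens) for inhibition, read by sulforhodamine B assay, with a stated time of 48 h; on this read-out lower numbers stand for stronger inhibition of growth and higher numbers for weaker inhibition of growth: compound 1 `COc1ccc(Sc2nc3cc(N)cc(N)c3nc2-c2ccccc2)cc1`, compound 2 `Nc1cc(N)c2nc(-c3ccccc3)c(Sc3ccc(Cl)c(Cl)c3)nc2c1`, compound 3 `Nc1cc(N)c2nc(-c3ccccc3)c(Oc3ccc(F)cc3)nc2c1`.

Compound 1 gives only a limit in this assay, < 100000 nM, (the limit of < 100000 nM in this assay, at which 1 of the 3 values shown sits). Compound 2 gives 57500 nM. Compound 3 gives 33900 nM, the lowest of the two numbers shown; its nearest neighbour is compound 2, and the step of a 1.7-fold lower number from compound 2 to compound 3 (0.23 log units; within the scatter) lies within the scatter. The steps a step that the limit leaves unreadable from compound 1 to compound 2 and a step that the limit leaves unreadable from compound 1 to compound 3 cannot be sized.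

Compound 4 `Nc1cc(N)c2nc(-c3ccccc3)c(Sc3ccc(F)cc3)nc2c1` differs from compound 3 by (4-fluorophenyl)sulfanyl in place of 4-fluorophenoxy on an aromatic carbon. For the measured compounds named here, the only readable comparison of a sulfanyl-linked with an oxygen-linked aryl group is a 1.7-fold lower number from compound 2 to compound 3 (0.23 log units; within the scatter), within the scatter, though the aryl ring also changes there. No step beyond the scatter is therefore expected; the expected step is a 1.3-fold higher number from compound 3 to compound 4 (0.12 log units; within the scatter). Compound 4 is estimated at 45000 nM (range 15000 nM to 130000 nM).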

Compound 4, concentration for total growth inhibition: 41700 nM
Beside the measured number, compound 4's estimate is 1.1-fold (0.03 log units) above it, within the range that was stated.
By their numbers in this assay, from the lowest: compounds 3, 4 and 2 (each within the scatter of the next).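

In this assay, for the compounds shown here, a 1.2-fold higher number from compound 3 to compound 4 (0.09 log units; within the scatter) is the first comparison of sulfur with oxygen as the link at this aromatic carbon with the aryl ring held constant, and it does not separate (4-fluorophenyl)sulfanyl from 4-fluorophenoxy. With sulfur held constant, a 1.4-fold lower number from compound 2 to compound 4 (0.14 log units; within the scatter) likewise does not separate 4-fluorophenyl from 3,4-dichlorophenyl. The step from compound 1 to compound 4 cannot be read, as compound 1 gives only a limit: the limit of < 100000 nM in this assay, at which 1 of the 4 values shown sits.

Every readable step in the series stays within the scatter. Open, on these data alone, is whether an amine link at this carbon, or a carboxylic acid on the aryl ring, would give a step beyond it.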